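A few compounds are considered here, and "the series" means these few. Any claim that something is new, unique, unknown or untested is made for them only; others in the source may bear on it.

Going by the values given here, compound 2 `Cc1ccc(C(=O)Nc2nc(-c3ccccc3)nc3c2nnn3Cc2ccccc2)cc1` gives the higher of the two numbers so far in an assay (strain Wistar) for displacement of a labelled ligand from adenosine receptor A1 (Rattus norvegicus), read by scintillation counting; on this read-out higher numbers stand for weaker inhibition and lower numbers for stronger inhibition: compound 2 gives 709 nM, whereas compound 1 `O=C(Nc1nc(-c2ccccc2)nc2c1nnn2Cc1ccccc1)c1cccc([N+](=O)[O-])c1` gives 77 nM, and the one step, a 9.2-fold higher number from compound 1 to compound 2 (0.96 log units; beyond the scatter), is the whole of what has been measured. Compound 3 `O=C(Nc1nc(-c2ccccc2)nc2c1nnn2Cc1ccccc1)C1CCCC1` differs from compound 2 by cyclopentyl in place of 4-methylphenyl on a carbonyl carbon. Among the compounds with values here, no measured step bears directly on exchanging an aromatic ring for a five-membered non-aromatic ring at this position; the only comparison available concerns two aromatic rings and changed this assay by a modest amount. With no closer guide, the expectation for compound 3 is a change of roughly that order or smaller, with the number for compound 3 estimated to be 1200 nM, between 300 nM and 5000 nM, which would mean an expected step of a 1.7-fold higher number from compound 2 to compound 3 (0.23 log units; within the scatter) in this assay.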

Compound 3, inhibition constant: 2.5 nM
For compound 3 the middle estimate is 480-fold (2.68 log units) above the measured one; the whole stated range lies above it.
By their numbers in this assay, from the lowest: compound 3; then compound 1; then compound 2.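

Exchanging 4-methylphenyl for cyclopentyl on the carbonyl carbon gives a 280-fold lower number from compound 2 to compound 3 (2.45 log units; beyond the scatter) in this assay, and exchanging 3-nitrophenyl for cyclopentyl gives a 31-fold lower number from compound 1 to compound 3 (1.49 log units; beyond the scatter). The earlier pair showed only a modest step between two aromatic groups, whereas these steps show that this position can move the number much further when a non-aromatic ring takes the place of either aromatic one, leaving compound 3 the strongest of the three. No evidence is available to explain the size of these steps.

The compounds shown do not separate the effect of the ring being non-aromatic from that of its size or of the substituents on the aromatic rings. Going by these compounds, whether an unsubstituted phenyl, a cyclohexyl or an open butyl chain would behave like cyclopentyl remains open.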